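Amino for hydroxy on a chloro-bearing core

The source may hold more compounds than are shown below. What is called first, only, known or untested is meant among the compounds shown, and "the series" means these compounds.

Measured in an assay on cells for inhibition of Indoleamine 2,3-dioxygenase 1 (Homo sapiens), read by HPLC, with a stated time of 20 min; on this read-out lower numbers stand for stronger inhibition and higher numbers for weaker inhibition:
compound 1 `Oc1ccccc1-c1nnc[nH]1` gives 31000 nM
compound 2 `Nc1ccccc1-c1nnc[nH]1` gives 2000 nM
compound 3 `Oc1ccc(Cl)cc1-c1nnn[nH]1` gives 16000 nM

Compound 4 `Nc1ccc(Cl)cc1-c1nnn[nH]1` is not yet measured. Going by the values given here, the change from compound 3 to compound 4, (amino in place of hydroxy on an aromatic carbon), is the same kind of change as the one from compound 1 to compound 2, (amino in place of hydroxy on an aromatic carbon); the place differs in that in compound 4 it is also para to a chloro group. The earlier change gave a 16-fold lower number from compound 1 to compound 2 (1.19 log units; beyond the scatter). How the core of compound 3 differs from the core of compound 1 is not broken down here; in this assay compound 3 and compound 1 give numbers within the scatter of each other. Among the compounds with values here, a step of similar size is expected from compound 3 to compound 4, a 13-fold lower number from compound 3 to compound 4 (1.12 log units; beyond the scatter), and this rests on the single earlier step of a 16-fold lower number from compound 1 to compound 2 (1.19 log units; beyond the scatter), with no second instance to show how far the change carries onto this core. Compound 4 is therefore estimated at 1200 nM in this assay, with the expected range running from 400 nM to 4000 nM.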

Compound 4, half-maximal inhibitory concentration: 220 nM
The estimate for compound 4 lay 5.5-fold (0.74 log units) above the measured number, and the stated range ends above it.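

In this assay, amino in place of hydroxy on the chloro-bearing core of compound 3 gives a 73-fold lower number from compound 3 to compound 4 (1.86 log units; beyond the scatter). The direction of the change carries from one core to the other, but its size does not stay the same: the same change on two cores in this assay, a 16-fold lower number (1.19 log units; beyond the scatter) from compound 1 to compound 2 and a 73-fold lower number (1.86 log units; beyond the scatter) from compound 3 to compound 4, 4.7-fold (0.67 log units) apart, beyond the scatter of two such steps Two pairs do not show which difference between the cores goes with the larger step, nor how the change would run on any further core in the series.

It remains open whether the larger step follows the chloro group or some other part of the core, as the compounds shown do not separate the two. Also open, from the compounds shown here alone, is how the amino compounds would respond to a fluoro or methyl group in place of the chloro group, or to a methylamino or acetamido group in place of the amino group.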